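Series notes: from compound 3 to compound 4

This account rests on a few compounds, and the source may have more. Where it says the series, first, only, none or still open, it means among the compounds named here.

Measured in a functional assay on PC-3 cells (Homo sapiens) for cytotoxicity, read by MTT assay, with a stated time of 72 h (a higher number here means a weaker inhibitor, a lower number a stronger inhibitor), so far:
compound 1 `FC(F)(F)c1ccc(CSc2nc(Nc3ccccc3C(F)(F)F)c3ccccc3n2)cc1` gives 34800 nM
compound 2 `FC(F)(F)c1ccc(CSc2nc(Nc3ccccc3Cl)c3ccccc3n2)cc1` gives 20400 nM
compound 3 `CCOc1ccccc1Nc1nc(SCc2ccc(C(F)(F)F)cc2)nc2ccccc12` gives 26200 nM

Compound 3 holds the second highest of the three numbers in this assay; its nearest neighbour is compound 2, a 1.3-fold higher number from compound 2 to compound 3 (0.11 log units; within the scatter), and its furthest is compound 1, a 1.3-fold lower number from compound 1 to compound 3 (0.12 log units; within the scatter). The remaining pair is no wider: a 1.7-fold lower number from compound 1 to compound 2 (0.23 log units; within the scatter). All three measured compounds therefore sit together within the scatter of this assay.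

Compound 4 `FC(F)(F)c1ccc(CSc2nc(Nc3cccc(C(F)(F)F)c3)c3ccccc3n2)cc1` is the next step: 3-(trifluoromethyl)phenyl in place of 2-ethoxyphenyl on a nitrogen on an aromatic ring. Going by the values given here, the only measured step that touches this change is the one from compound 1 to compound 3, a 1.3-fold lower number from compound 1 to compound 3 (0.12 log units; within the scatter), read here in reverse; it lay within the scatter. Among the compounds with values here, the shift of the group to a different place on that ring has no measured counterpart. With nothing shown moving beyond the scatter, compound 4 is expected to stay in the same band: a 1.1-fold higher number from compound 3 to compound 4 (0.06 log units; within the scatter). The estimate for compound 4 in this assay is 30000 nM, with a range of 12000 nM to 80000 nM.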

Compound 4, half-maximal inhibitory concentration: 12900 nM
Compound 4: middle estimate off by 2.3-fold (0.37 log units), on the high side, and the stated range covers the measured number.
By their numbers in this assay, from the lowest: compounds 4, 2, 3 and 1 (each within the scatter of the next, the first and the last beyond it).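

In this assay, changing the group on the nitrogen now gives steps beyond the scatter: a 2.0-fold lower number from compound 3 to compound 4 (0.31 log units; beyond the scatter) and a 2.7-fold lower number from compound 1 to compound 4 (0.43 log units; beyond the scatter), while a 1.6-fold lower number from compound 2 to compound 4 (0.20 log units; within the scatter) leaves compound 2 and compound 4 without an order. Going by these compounds alone, the step to compound 4 from compound 1 is the cleanest reading, since 2-(trifluoromethyl)phenyl and 3-(trifluoromethyl)phenyl carry the same group, so where trifluoromethyl sits on that ring alone moves the number, which the earlier compounds could not show. Nothing available accounts for this shift.

Still open, as far as these compounds go, is whether chloro or ethoxy would respond to the same relocation as trifluoromethyl does, and whether an amine or a carboxylic acid at that place on the ring would extend the step. The rest of the shared core is unchanged across these compounds, so its contribution cannot be judged.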